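The source may report more compounds than this note shows. Statements on the series, on what has been measured and on what is new or still open speak of the compounds shown alone.

Compound 1 `O=C1C=C(N2CCN(c3ccc(Br)cc3)CC2)C(=O)c2ccccc21`: > 50000 nM
Compound 2 `Cc1ccc(N2CCN(C3=CC(=O)c4ccccc4C3=O)CC2)cc1`: 8200 nM

Of the compounds shown here, two have been measured in a functional assay on DU-145 cells (Homo sapiens) for inhibition, read by MTT assay, with a stated time of 72 h; on this read-out higher numbers stand for weaker inhibition and lower numbers for stronger inhibition. Compound 1 gives only a limit, > 50000 nM, and not a number. Among the compounds with values here, compound 2, carrying methyl in place of bromo on an aromatic carbon, gives 8200 nM in this assay, the only actual number among the two values shown. The value of compound 1 is a limit, (the limit of > 50000 nM in this assay, at which 1 of the 2 values shown sits). The step of an at least 6.0-fold lower number from compound 1 to compound 2 (0.78 log units; beyond the scatter) is therefore bounded by that limit and can only be read as an at-least figure.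

Compound 3 `Cc1cccc(N2CCN(C3=CC(=O)c4ccccc4C3=O)CC2)c1` has not yet been measured in this assay. It differs from compound 2 in one place: 3-methylphenyl in place of 4-methylphenyl on an amine nitrogen in a ring The two structures hold the same atoms, joined differently; each carries a methylphenyl on an amine nitrogen in a ring.

Within the data shown here, no measured step shifts a methyl from one aromatic carbon to another; the single measured step exchanges methyl for bromo and does not touch the place of the group. Nothing shown supports expecting a step beyond the scatter. Compound 3 is expected to give 8000 nM, between 3000 nM and 25000 nM. The step this estimate implies, a 1.0-fold lower number from compound 2 to compound 3 (0.01 log units; within the scatter), is expected to stay within the scatter.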

Compound 3, half-maximal inhibitory concentration: 7400 nM
Estimate against measurement, compound 3: 1.1-fold (0.03 log units) above, within the range that was stated.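

In this assay, shifting the methyl so that 3-methylphenyl stands in place of 4-methylphenyl on the amine nitrogen in the ring gives a 1.1-fold lower number from compound 2 to compound 3 (0.04 log units; within the scatter), the first step shown that changes where a group sits on the phenyl and not which group it is, and across this one change compound 2 and compound 3 cannot be told apart. The exchange of 4-bromophenyl for 3-methylphenyl at the same place gives an at least 6.7-fold lower number from compound 1 to compound 3 (0.82 log units; beyond the scatter), so both methylphenyl compounds now have a readable number, whichever of these two places holds the methyl. That step is only an at-least figure, as the value of compound 1 is a limit and not a number: the limit of > 50000 nM in this assay, at which 1 of the 3 values shown sits.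

The compounds shown leave open how 3-bromophenyl on the same amine nitrogen would read in this assay, and so whether the limit seen with bromo holds at both places on the phenyl. They also leave open how a chloro or methoxy group on the phenyl, or an ethyl in place of the methyl, would read, and whether any such group would give a step beyond the scatter from compound 3.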